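A few compounds are considered here, and "the series" means these few. Any claim that something is new, unique, unknown or untested is made for them only; others in the source may bear on it.

In a functional assay on PANC-1 cells (Homo sapiens) for inhibition, read by MTT assay, with a stated time of 24 h, tested at 10 uM (on this read-out lower numbers stand for less inhibition and higher numbers for more inhibition at the one concentration tested (going by the name of the read-out)), three close analogues have been measured. Compound 1 `CC(C)=CCC/C(C)=C/CC1Cc2c(OCc3ccccc3)cc(=O)n(CCCO)c2CC1(C)C` gives 1.5%. Compound 2 `COc1ccc(NC(=O)Oc2cc(=O)n(CCCO)c3c2CC(C/C=C(\C)CCC=C(C)C)C(C)(C)C3)cc1` gives 0%, and compound 3 `COc1cccc(NC(=O)Oc2cc(=O)n(CCCO)c3c2CC(C/C=C(\C)CCC=C(C)C)C(C)(C)C3)c1` gives 11.3%. Compound 3 stands highest of the three numbers; its gap to compound 1 lies within the scatter, while the step of a number 11.3 percentage points higher from compound 2 to compound 3 (beyond the scatter) lies beyond it. Compound 4 `CC(C)=CCC/C(C)=C/CC1Cc2c(OC(=O)Nc3ccc(F)cc3)cc(=O)n(CCCO)c2CC1(C)C` has not yet been measured in this assay. It differs from compound 3 in one place: 4-fluorophenyl in place of 3-methoxyphenyl on an amide-type nitrogen. Among the compounds with values here, the only measured step that touches the group on the amide-type nitrogen is a number 11.3 percentage points higher from compound 2 to compound 3 (beyond the scatter), where 3-methoxyphenyl replaced 4-methoxyphenyl. The other two steps, a number 1.5 percentage points lower from compound 1 to compound 2 (within the scatter) and a number 9.8 percentage points higher from compound 1 to compound 3 (within the scatter), concern the carbamoyl group replacing benzyl and say little about the aryl ring itself. Compound 2, with 4-methoxyphenyl in that place, gives 0%. The step of a number 7.3 percentage points lower from compound 3 to compound 4 (within the scatter) is therefore expected to run downward, resting on that number of compound 2. Compound 4 is expected to give 4% in this assay, between 0% and 15%.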

Compound 4, a percentage reported as inhibition, at one concentration (the size of the read-out at that concentration, not a potency): 6.2%
Compound 4: the middle estimate sits 2.2 percentage points below what was measured; measured number inside the range.
By their numbers in this assay, from the lowest: compounds 2, 1, 4 and 3 (each within the scatter of the next, the first and the last beyond it).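

In this assay, 4-fluorophenyl on the amide-type nitrogen cannot be told apart from either methoxyphenyl group: a number 5.1 percentage points lower from compound 3 to compound 4 (within the scatter) and a number 6.2 percentage points higher from compound 2 to compound 4 (within the scatter) both lie within the scatter, although compound 2 and compound 3 are separated beyond it. Compound 4 therefore bridges that pair, and fluoro in place of methoxy gives no clear change on this aryl ring. The step of a number 4.7 percentage points higher from compound 1 to compound 4 (within the scatter) also lies within the scatter, so this carbamoyl group, like the two methoxyphenyl carbamoyl groups, is not separated from benzyl on the oxygen, and nothing measured here offers an explanation for these numbers.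

From the compounds shown here alone, what remains open is whether any other group on the amide-type nitrogen, such as a 4-aminophenyl, a 4-carboxyphenyl or a longer alkyl chain, would move the number clearly beyond the scatter. Going by these compounds, it is also open whether the 3-methoxyphenyl result reflects that placement of the methoxy group or something more general about groups at that place on the ring.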